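A few compounds are considered here, and "the series" means these few. Any claim that something is new, unique, unknown or untested is made for them only; others in the source may bear on it.

Measured so far in a functional assay on HCT-15 cells (Homo sapiens) for inhibition; a higher number here means a weaker inhibitor, a lower number a stronger inhibitor:
compound 1, `Oc1ccc(-c2cc(-c3ccccc3C(F)(F)F)cc(-c3ccc(O)cc3)n2)cc1` — a limit, > 50000 nM
compound 2, `Oc1ccc(-c2cc(-c3cccc(C(F)(F)F)c3)cc(-c3ccc(O)cc3)n2)cc1` — a limit, > 50000 nM

Compound 2 stands only at a limit of this assay, not at a number. Compound 1 sits at the same limit, so the step that the two limits leave unreadable from compound 1 to compound 2 cannot be read in either direction; both values rest at the limit of > 50000 nM in this assay, at which 2 of the 2 values shown sit. Among the compounds with values here, the series so far gives no readable step at all.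

Compound 3, `Oc1ccc(-c2cc(-c3cccc(OC(F)(F)F)c3)cc(-c3ccc(O)cc3)n2)cc1`, differs from compound 2 in one place: trifluoromethoxy in place of trifluoromethyl on an aromatic carbon. Within the data shown here, no measured step bears on this change, and the only measured step, the one from the 2-substituted to the 3-substituted ring, is itself unreadable. Nothing in the numbers points to a move away from the limit, so the step from compound 2 to compound 3 is expected to be a number no higher from compound 2 to compound 3 (the limit leaves the size open), none beyond the scatter. Compound 3 is therefore estimated at 50000 nM in this assay, within 20000 nM to 100000 nM, most likely again reported only as a limit.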

Compound 3, half-maximal inhibitory concentration: > 50000 nM
Compound 3 was reported as a limit (the forecaster's own chance of this, stated with the estimate: 80%); the middle value sits exactly at the limit.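

In this assay compound 3 is again a limit, > 50000 nM, so no step can be read between compound 2 and compound 3; the series rests at one limit: the limit of > 50000 nM in this assay, at which 3 of the 3 values shown sit.

The compounds shown leave open how the trifluoromethyl and trifluoromethoxy compounds rank in this assay, and whether any change to the shared core gives a measurable value.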